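Working notes: from compound 1 to compound 3

A few compounds are considered here, and "the series" means these few. Any claim that something is new, unique, unknown or untested is made for them only; others in the source may bear on it.

Measured so far:
compound 1 `COc1ccc(CN(C(=O)Nc2ccc(C#N)cc2)n2cnnc2)cc1OC`: in a functional assay on MCF7 cells (Homo sapiens) for cytotoxicity, read by MTT assay, with a stated time of 48 h (on this read-out higher numbers stand for weaker inhibition and lower numbers for stronger inhibition), compound 1 gives > 50000 nM, which is a limit of the assay.
compound 2 `COc1cc(CN(C(=O)Nc2ccc(C#N)cc2)n2cnnc2)cc(OC)c1OC`: in this assay compound 2 gives > 50000 nM, likewise a limit.

Going by the values given here, compound 1 stands only at a limit, and its single measured neighbour, compound 2, stands at the same limit. The step that the two limits leave unreadable from compound 1 to compound 2 is therefore not readable, and the limit of > 50000 nM in this assay, at which 2 of the 2 values shown sit, is all that the two values show. Compound 3 `CCc1ccc(NC(=O)N(Cc2ccc(OC)c(OC)c2)n2cnnc2)cc1` differs from compound 1 by ethyl in place of cyano on an aromatic carbon. Among the compounds with values here, no measured step bears on this change: the only step in the set concerns methoxy in place of hydrogen, and its size cannot be read. With both measured compounds at the limit, nothing in the data points to a move in either direction beyond the scatter. The step estimated here in this assay is a number no higher from compound 1 to compound 3 (the limit leaves the size open). Compound 3 is accordingly expected at 50000 nM, within 20000 nM to 100000 nM, and most probably as a limit once more.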

Compound 3, half-maximal inhibitory concentration: > 50000 nM
Compound 3: only a limit was reported (the forecaster's own chance of this, stated with the estimate: 80%); the middle value sits exactly at the limit.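

Compound 3 gives only a limit, as do compound 1 and compound 2, so no step can be read among them: the limit of > 50000 nM in this assay, at which 3 of the 3 values shown sit.

The compounds shown leave open whether ethyl in place of cyano, or methoxy in place of hydrogen, shifts the response in this assay.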